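Amide-to-urea switch in the pyrazole series

A few compounds are considered here, and "the series" means these few. Any claim that something is new, unique, unknown or untested is made for them only; others in the source may bear on it.

Measured so far:
compound 1 `O=C(Nc1cccc(-n2cc(-c3ccncc3)c(-c3ccc(Cl)c(O)c3)n2)c1)Nc1cccc(C(F)(F)F)c1` – 4970 nM
compound 2 `COc1cc(-c2nn(-c3cccc(NC(=O)c4cccc(C(F)(F)F)c4)c3)cc2-c2ccncc2)ccc1Cl` – 2290 nM
compound 3 `O=C(Nc1cccc(-n2cc(-c3ccncc3)c(-c3ccc(Cl)c(O)c3)n2)c1)Nc1ccc(Cl)c(Cl)c1` – 1200 nM

In a functional assay on SK-OV-3 cells (Homo sapiens) for inhibition, read by sulforhodamine B assay, with a stated time of 48 h (on this read-out lower numbers stand for stronger inhibition of growth and higher numbers for weaker inhibition of growth), compound 2 gives 2290 nM, the second highest of the three numbers; the gap to compound 3 lies within the scatter, that to compound 1 beyond it. Compound 4 `COc1cc(-c2nn(-c3cccc(NC(=O)Nc4cccc(C(F)(F)F)c4)c3)cc2-c2ccncc2)ccc1Cl` carries (3-(trifluoromethyl)phenyl)amino in place of 3-(trifluoromethyl)phenyl on a carbonyl carbon. For the measured compounds named here, the single measured step, a 4.1-fold lower number from compound 1 to compound 3 (0.62 log units; beyond the scatter), changes a different part of the molecule and does not bear on this change. Compound 1 shares the new (3-(trifluoromethyl)phenyl)amino with compound 4 but also differs from compound 2 at the hydroxy against methoxy, so the values of compound 1 and compound 2 only show that compound 1 sits higher. For compound 4 a step of a 1.5-fold higher number from compound 2 to compound 4 (0.18 log units; within the scatter) is expected, a slight rise that may well stay within the scatter. The estimate for compound 4 is 3500 nM, range 1500 nM to 8000 nM.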

Compound 4, concentration for 50% growth inhibition: 2020 nM
Compound 4: middle estimate off by 1.7-fold (0.24 log units), on the high side, within the range that was stated.
By their numbers in this assay, from the lowest: compounds 3, 4 and 2 (each within the scatter of the next); then compound 1.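

In this assay, (3-(trifluoromethyl)phenyl)amino in place of 3-(trifluoromethyl)phenyl on a carbonyl carbon gives a 1.1-fold lower number from compound 2 to compound 4 (0.05 log units; within the scatter), so with the methoxy present the urea and the amide cannot be told apart at this position. Methyl in place of hydrogen on the oxygen on the aromatic ring gives a 2.5-fold lower number from compound 1 to compound 4 (0.39 log units; beyond the scatter), the first reading of that change with the rest of the molecule held constant. No evidence is available that explains either step. Still open, as far as these compounds go, is whether an ethoxy or an amino group in place of the methoxy would follow the same direction.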